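Replacing an Aromatic Group with a Short Chain

A few compounds are considered here, and "the series" means these few. Any claim that something is new, unique, unknown or untested is made for them only; others in the source may bear on it.

Of the compounds shown here, three sharing one core have been measured in an assay on CHO-K1 cells for displacement of a labelled ligand from adenosine receptor A1 (Homo sapiens), read by scintillation counting, with a stated time of 60 min; a lower number here means a stronger inhibitor, a higher number a weaker inhibitor. Compound 1 `CC(/C=N/Nc1nc(N)c2ncn([C@@H]3O[C@H](CO)[C@@H](O)[C@H]3O)c2n1)Cc1ccc(C(C)C)cc1` gives 9500 nM, compound 2 `Nc1nc(N/N=C/c2ccc(N3CCCC3)cc2)nc2c1ncn2[C@@H]1O[C@H](CO)[C@@H](O)[C@H]1O` gives 5.1 nM, and compound 3 `COc1cc(/C=N/Nc2nc(N)c3ncn([C@@H]4O[C@H](CO)[C@@H](O)[C@H]4O)c3n2)ccc1OCc1ccccc1` gives 9140 nM. Compound 2 thus has the lowest number of the three, and both other compounds lie far above it, well beyond the usual scatter, so compound 2 is the strongest inhibitor in this set.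

Compound 4 `CSCC/C=N/Nc1nc(N)c2ncn([C@@H]3O[C@H](CO)[C@@H](O)[C@H]3O)c2n1` has not yet been measured in this assay. It differs from compound 2 in a single place: 2-(methylsulfanyl)ethyl in place of 4-(pyrrolidin-1-yl)phenyl on a carbon with a double bond to nitrogen. In compound 2 the group attached at that carbon is the larger 4-(pyrrolidin-1-yl)phenyl; in compound 4 it is the smaller 2-(methylsulfanyl)ethyl.

Among the measured compounds shown here, no pair of measured compounds differs in only this way, so the effect of the change is not known from a direct comparison. Compound 1, which also carries a non-aromatic chain at that carbon, gives a much higher number than compound 2, and compound 3, which carries a different aromatic group, likewise gives a much higher number. On that basis a large step upward, toward a weaker inhibitor, is expected from compound 2 to compound 4, a 590-fold higher number from compound 2 to compound 4 (2.77 log units; beyond the scatter). Compound 4 is therefore estimated at 3000 nM, with a range from 400 nM to 20000 nM.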

Compound 4, inhibition constant: > 10000 nM
Compound 4: no number, only a limit; the forecaster's own chance of this, stated with the estimate: 10%; middle value at least 3.3-fold (0.52 log units) away from the limit.
By their numbers in this assay, from the lowest: compound 2; then compounds 3 and 1 (each within the scatter of the next). At a limit, above all of these: compound 4.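

In this assay compound 4 gives > 10000 nM, which is a limit of the assay and not a number. Among the compounds shown here, this is the first comparison here in which only one group changes: putting 2-(methylsulfanyl)ethyl in place of 4-(pyrrolidin-1-yl)phenyl on a carbon with a double bond to nitrogen gives an at least 1900-fold higher number from compound 2 to compound 4 (3.29 log units; beyond the scatter), so the strength of compound 2 does not survive this exchange. The step is a lower bound, so its true size remains unknown, and the reading for compound 4 rests on: the limit of > 10000 nM in this assay, at which 1 of the 4 values shown sits.

The exchange removes a five-membered non-aromatic ring and a six-membered aromatic ring together and brings in a sulfur-containing chain, so this single step cannot show which of these differences accounts for the loss. A plain phenyl group or a 4-(dimethylamino)phenyl group at this carbon could separate the contribution of each ring, while a longer carbon chain could test whether chain length alone matters.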